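The source may report more compounds than this note shows. Statements on the series, on what has been measured and on what is new or still open speak of the compounds shown alone.

Measured compounds:
compound 1, `CCCCCCCCc1ccc(OCC(=O)Cn2nnnc2-c2ccccc2)cc1`, 71 nM
compound 2, `CCCCCCCCc1ccc(OCC(=O)Cn2nnnc2C(=O)OC)cc1`, 1000 nM

The account follows the step from compound 2 to compound 3. In an assay on microsomes from brain for inhibition of Fatty-acid amide hydrolase 1 (Rattus norvegicus), read by fluorescence and HPLC, with a stated time of 60 min (on this read-out higher numbers stand for weaker inhibition and lower numbers for stronger inhibition), compound 2 gives 1000 nM, the highest of the two numbers measured; its nearest neighbour is compound 1, which in this assay gives 71 nM. Compound 3, `CCCCCCCCc1ccc(OCC(=O)Cn2nnnc2-c2ccc(C(=O)O)cc2)cc1`, differs from compound 2 in one place: 4-carboxyphenyl in place of methoxycarbonyl on an aromatic carbon. For the measured compounds named here, the only step that bears on this change is a 14-fold higher number from compound 1 to compound 2 (1.15 log units; beyond the scatter), where a phenyl on that same aromatic carbon went with the lower number. Going by the values given here, compound 3 restores a six-membered aromatic ring at that position, but carries a carboxylic acid on it, for which no measured pair exists. A lower number than compound 2 is therefore expected, though with wide uncertainty, the step being estimated as a 3.3-fold lower number from compound 2 to compound 3 (0.52 log units; beyond the scatter). Compound 3 is estimated at 300 nM, within the range 50 nM to 2000 nM.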

Compound 3, half-maximal inhibitory concentration: 3400 nM
The estimate for compound 3 lay 11-fold (1.05 log units) below the measured number; measured number above the stated range.
By their numbers in this assay, from the lowest: compound 1; then compound 2; then compound 3.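

In this assay, compound 1 and compound 2 alone tied the lower number to a phenyl on this carbon, but that link does not hold for every six-membered aromatic ring here. Carboxy in place of hydrogen on that phenyl gives a 48-fold higher number from compound 1 to compound 3 (1.68 log units; beyond the scatter), and 4-carboxyphenyl in place of methoxycarbonyl gives a 3.4-fold higher number from compound 2 to compound 3 (0.53 log units; beyond the scatter), so the substituted ring ends above even the methoxycarbonyl group and the substituent on the phenyl counts for more than the presence of the ring itself. Nothing available accounts for this result.

As far as these compounds go, it remains open whether a methyl ester, an amide or a hydroxymethyl on that phenyl would give a number nearer that of compound 1 or that of compound 3. From the compounds shown here alone, whether carboxy would produce a similar step on another carbon of that ring also stays open.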